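Tert-butyl for trifluoromethyl: an expected step

This account rests on a few compounds, and the source may have more. Where it says the series, first, only, none or still open, it means among the compounds named here.

The compounds measured so far:
compound 1, `COc1cc2nc(N3CCN(S(=O)(=O)c4ccc(Br)cc4)CC3)nc(N)c2cc1OC`, giving 20000 nM in a functional assay on PC-3 cells (Homo sapiens) for inhibition; a higher number here means a weaker inhibitor, a lower number a stronger inhibitor
compound 2, `COc1cc2nc(N3CCN(S(=O)(=O)c4ccc(-c5ccc(C(F)(F)F)cc5)cc4)CC3)nc(N)c2cc1OC`, giving 3300 nM in this assay

For the measured compounds named here, compound 2 stands at the lowest of the two numbers; the only other compound, compound 1, sits higher, and the single measured step reads a 6.1-fold lower number from compound 1 to compound 2 (0.78 log units; beyond the scatter). Compound 3, `COc1cc2nc(N3CCN(S(=O)(=O)c4ccc(-c5ccc(C(C)(C)C)cc5)cc4)CC3)nc(N)c2cc1OC`, differs from compound 2 by tert-butyl in place of trifluoromethyl on an aromatic carbon. Going by the values given here, no measured step exchanges one such group for another: the only step on record, a 6.1-fold lower number from compound 1 to compound 2 (0.78 log units; beyond the scatter), replaces bromo by a whole 4-(trifluoromethyl)phenyl and so does not bear directly on this smaller exchange. With nothing to point either way, the expected step is a 1.1-fold lower number from compound 2 to compound 3 (0.04 log units; within the scatter), within the usual scatter. In this assay compound 3 is therefore estimated at 3000 nM, with a range from 1000 nM to 9000 nM.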

Compound 3, half-maximal inhibitory concentration: 10000 nM
For compound 3 the middle estimate is 3.3-fold (0.52 log units) below the measured one; the whole stated range lies below it.
By their numbers in this assay, from the lowest: compound 2; then compounds 3 and 1 (each within the scatter of the next).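

In this assay, the para substituent on this six-membered aromatic ring matters even when the count of heavy atoms stays the same: tert-butyl in place of trifluoromethyl gives a 3.0-fold higher number from compound 2 to compound 3 (0.48 log units; beyond the scatter). The phenyl extension alone therefore does not secure the gain seen in compound 2, since the 4-(tert-butyl)phenyl group gives a 2.0-fold lower number from compound 1 to compound 3 (0.30 log units; within the scatter), leaving compound 3 not distinguishable from the bromo compound 1. Nothing available here accounts for the difference between these two groups.

With only two groups compared at this place, the compounds shown set no trend. As far as these compounds go, how a plain phenyl, or one carrying a methoxy, a nitrile, an amine or a carboxylic acid in the same place, would compare with compound 2 remains open.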